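The source may report more compounds than this note shows. Statements on the series, on what has been measured and on what is new or still open speak of the compounds shown alone.

Measured in a functional assay on RAW264.7 cells (Mus musculus) for cytotoxicity, read by MTT assay, with a stated time of 48 h; on this read-out higher numbers stand for weaker inhibition and lower numbers for stronger inhibition:
Compound 1 `CS(=O)(=O)c1ccc(Cc2nnc3n2N=C(c2ccc(-c4ccccc4)cc2)CS3)cc1`: 12500 nM
Compound 2 `CS(=O)(=O)c1ccc(Cc2nnc3n2N=C(c2cc(Cl)sc2Cl)CS3)cc1`: > 100000 nM (a limit)
Compound 3 `CS(=O)(=O)c1ccc(Cc2nnc3n2N=C(c2cc4ccccc4c(=O)o2)CS3)cc1`: > 100000 nM (a limit)

All three compounds share one core. Compound 2 stands at the end of the measurable range: its > 100000 nM is a limit and not a number. Compound 3 likewise gives only a limit, > 100000 nM. Going by the values given here, the series so far is thus dominated by the limit of > 100000 nM in this assay, at which 2 of the 3 values shown sit. Compound 1 goes against that pattern, since compound 1 alone gives a number, 12500 nM.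

Compound 4 `CS(=O)(=O)c1ccc(Cc2nnc3n2N=C(c2ccc(O)c(C(N)=O)c2)CS3)cc1` has the shared core and carries 3-carbamoyl-4-hydroxyphenyl in place of 2,5-dichlorothiophen-3-yl on a carbon with a double bond to nitrogen. Among the compounds with values here, no measured step shows directly what such an exchange does. In this assay no step beyond the scatter is expected for compound 4, in either direction, because the limit of > 100000 nM in this assay, at which 2 of the 3 values shown sit, includes compound 2. The estimated change is a number no higher from compound 2 to compound 4 (the limit leaves the size open). Compound 4 is estimated at 100000 nM, with an expected range of 30000 nM to 200000 nM.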

Compound 4, half-maximal inhibitory concentration: > 100000 nM
Compound 4 ended at the assay's limit (the forecaster's own chance of this, stated with the estimate: 65%); the middle value lies on the limit itself.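

In this assay compound 4 gives > 100000 nM, which is a limit and not a number. Going by these compounds alone, compound 2 also stands at a limit, so no step between compound 2 and compound 4 can be read. The compounds shown leave open whether 3-carbamoyl-4-hydroxyphenyl and 2,5-dichlorothiophen-3-yl differ at all in this assay.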